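The compounds below may be only part of what the source reports. "The series", "measured", "known", "first", "only" and "open" are said of these compounds alone.

Compound 1 `CS(=O)(=O)Nc1cccc2c1CCC2c1ncc[nH]1` was tested in a functional assay on CHO cells for agonist activity at Alpha-1D adrenergic receptor (Homo sapiens), read by FLIPR and calcium flux; a higher number here means that more compound is needed for the effect, a lower number that less compound is needed. In this assay compound 1 gives only a limit, > 10000 nM, and not a number. Compound 2 `COc1c(Cl)ccc2c1CCC2c1ncc[nH]1` also reaches only a limit in this assay, > 10000 nM. Compound 3 `Cc1c(OCC2=NCCN2)ccc(Cl)c1NS(C)(=O)=O` likewise stops at a limit in this assay, > 10000 nM. Compound 1 therefore stands exactly where the other two stand, at the limit of > 10000 nM in this assay, at which 3 of the 3 values shown sit, and no ordering among the three can be drawn.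

Compound 4 `Cc1oncc1-c1cccc2c1CCC2c1ncc[nH]1` has not yet been measured. It differs from compound 1 in one place: 5-methyl-1,2-oxazol-4-yl in place of methanesulfonamido on an aromatic carbon. Among the measured compounds shown here, no measured pair of compounds differs in a single place, so no measured step shows what such a change does. With compound 1 sitting at a limit, the direction of the step can only be estimated, and the expected step is a step that the limit leaves unreadable from compound 1 to compound 4, which is no change beyond the usual scatter. In this assay compound 4 is expected to give about 20000 nM, within a range from 4000 nM to 100000 nM, and most likely again only as a limit.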

Compound 4, half-maximal effective concentration: > 10000 nM
Compound 4 was reported as a limit; the forecaster's own chance of this, stated with the estimate: 70%; the middle value does not contradict the limit.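

Compound 1 and compound 4 both stop at a limit in this assay, so no step can be read between them: the limit of > 10000 nM in this assay, at which 4 of the 4 values shown sit.

The compounds shown leave open how much of each would be needed for the effect, and whether swapping methanesulfonamido for 5-methyl-1,2-oxazol-4-yl makes any difference.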